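Trifluorophenyl cinnamide: expected cytotoxicity in the benzophenone series

A few compounds are considered here, and "the series" means these few. Any claim that something is new, unique, unknown or untested is made for them only; others in the source may bear on it.

Measured compounds:
compound 1 `COc1ccc(/C=C/C(=O)Nc2cc(C(=O)c3cc(OC)c(OC)c(OC)c3)ccc2OC)cc1`: 5010 nM
compound 2 `COc1ccc(C(=O)c2cc(OC)c(OC)c(OC)c2)cc1NC(=O)/C=C/c1ccc([N+](=O)[O-])cc1`: 5100 nM
compound 3 `COc1ccc(/C=C/C(=O)Nc2cc(C(=O)c3cc(OC)c(OC)c(OC)c3)cc(OC)c2OC)cc1`: 3800 nM

All three numbers come from a functional assay on HT-29 cells (Homo sapiens) for cytotoxicity, read by MTT assay, with a stated time of 72 h; a lower number here means a stronger inhibitor, a higher number a weaker inhibitor. Compound 1 gives 5010 nM, and the nitro-for-methoxy exchange gives a 1.0-fold higher number from compound 1 to compound 2 (0.01 log units; within the scatter). Adding a methoxy to the central ring gives a 1.3-fold lower number from compound 1 to compound 3 (0.12 log units; within the scatter), so compound 3 sits at the low end of the three values, but every gap among them stays within the scatter; no ordering can be read from this set.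

Compound 4 `COc1cc(C(=O)c2cc(OC)c(OC)c(OC)c2)cc(NC(=O)/C=C/c2cc(F)c(F)c(F)c2)c1OC` keeps the core of compound 3 and changes only the aryl on the cinnamide: 3,4,5-trifluorophenyl in place of 4-methoxyphenyl on a double-bonded chain carbon bound to a double-bonded chain carbon. Among the measured compounds shown here, no measured step covers this exact exchange. For the measured compounds named here, the one step that touches the same ring, from compound 1 to compound 2, swapped one substituent on that ring and gave a 1.0-fold higher number from compound 1 to compound 2 (0.01 log units; within the scatter), i.e. no movement beyond the scatter. On that basis the expectation for this assay is a step of about a 1.1-fold higher number from compound 3 to compound 4 (0.02 log units; within the scatter), that is, no change beyond the scatter in either direction. Compound 4 is therefore estimated at 4000 nM, with a range from 1500 nM to 12000 nM.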

Compound 4, half-maximal inhibitory concentration: 3300 nM
Beside the measured number, compound 4's estimate is 1.2-fold (0.08 log units) above it; low and high end bracket the measured number.
By their numbers in this assay, from the lowest: compounds 4, 3, 1 and 2 (each within the scatter of the next).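

In this assay, replacing the whole aryl group on the cinnamide, with 4-methoxyphenyl leaving and 3,4,5-trifluorophenyl entering, gives a 1.2-fold lower number from compound 3 to compound 4 (0.06 log units; within the scatter). This goes further than the earlier step on that ring, which exchanged one substituent on a different core. Here the methoxy is gone, three fluorines are present, and the hydrogen-bond acceptor count of the group falls from 1 to 0, yet the number still does not move beyond the scatter; in both steps at this ring, then, the change leaves the value within the scatter, on the core of compound 1 as well as on the core of compound 3. No measurement available here accounts for this flat response, and nothing in hand bears on its origin.

The compounds shown leave open whether any replacement at this place can move the number beyond the scatter in this assay, for example an amine or a carboxylic acid on the aryl ring, or a longer chain in place of the ethenyl link. With all four values within the scatter of one another, the series as shown gives no ordering from which to pick a preferred aryl group.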